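From triazolyl to pyrazolyl on a carbonyl carbon

The source may report more compounds than this note shows. Statements on the series, on what has been measured and on what is new or still open speak of the compounds shown alone.

- Compound 1 `O=C(c1cn[nH]c1)N1CCC(C(=O)N2N=CCC2c2ccccc2)CC1` gives 2.1
- Compound 2 `O=C(c1c[nH]nn1)N1CCC(C(=O)N2N=CCC2c2ccccc2)CC1` gives 2

Measured in a physicochemical assay for lipophilicity, read by HPLC, measured as chromatographic lipophilicity, at pH 7.4 (a higher number here means a more lipophilic compound, a lower number a more polar compound), compound 2 stands level with compound 1 within the scatter, and no other number is available yet. Compound 3 `O=C(c1cc[nH]n1)N1CCC(C(=O)N2N=CCC2c2ccccc2)CC1` is still unmeasured. Its change from compound 2 is 1H-pyrazol-3-yl in place of 1H-1,2,3-triazol-4-yl on a carbonyl carbon and amounts to 1H-pyrazol-3-yl in place of 1H-1,2,3-triazol-4-yl on a carbonyl carbon. For the measured compounds named here, the only guide is the step of a number 0.10 log units lower from compound 1 to compound 2 (within the scatter) for 1H-1,2,3-triazol-4-yl in place of 1H-pyrazol-4-yl on a carbonyl carbon. One step is thin evidence, but nothing beyond the scatter is expected in this assay here. The expected step is a number 0.10 log units higher from compound 2 to compound 3 (within the scatter) and no larger. For compound 3 the estimate is 2.1 with an expected range from 1.8 to 2.4 in this measurement.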

Compound 3, distribution coefficient: 2.4
Estimate against measurement, compound 3: 0.30 log units below, within the range that was stated.
By their numbers in this assay, from the lowest: compounds 2, 1 and 3 (each within the scatter of the next, the first and the last beyond it).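

In this assay, for the compounds shown here, the choice of ring on this carbonyl carbon can matter: 1H-pyrazol-3-yl in place of 1H-1,2,3-triazol-4-yl gives a number 0.40 log units higher from compound 2 to compound 3 (beyond the scatter), the first step here to clear the scatter. The two pyrazolyl groups, by contrast, stand level, with a number 0.30 log units higher from compound 1 to compound 3 (within the scatter) between them. No measurement at hand gives a reason for this step. Still open, going by these compounds, is how an imidazolyl or tetrazolyl group would read on this carbonyl carbon. Also open, on these data alone, is whether the step would hold on a different core.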